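Quinazoline-diamine series: cytotoxicity on macrophage cells

The source may report more compounds than this note shows. Statements on the series, on what has been measured and on what is new or still open speak of the compounds shown alone.

Measured compounds:
- compound 1, `CC(C)Nc1nc(NCc2ccco2)c2ccccc2n1`: 17000 nM
- compound 2, `CC(C)Nc1nc(NC2CCCCC2)c2ccccc2n1`: "not determined" (no result reported)

Among the compounds with values here, compound 1 is the only member of the series with a number in an ADME assay on J774.A1 cells (Mus musculus) for cytotoxicity, read by MTT assay, with a stated time of 72 h; a lower number here means that less compound is needed, a higher number that more compound is needed for the effect. Within the data shown here, compound 2 carries no value there, its entry reading "not determined" (no result reported), so no step between measured compounds can be drawn and compound 1 stands alone as the reference point; it cannot be ranked against anything.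

Compound 3, `COc1ccc2nc(NC(C)C)nc(NCc3ccco3)c2c1`, has not yet been measured in this assay. It differs from compound 1 by methoxy in place of hydrogen on an aromatic carbon of the shared core. With no measured step of this kind in the series, there is nothing to scale the change against, and the expectation rests on compound 1 alone.

The step from compound 1 to compound 3 in this assay is expected to be small, a 1.1-fold lower number from compound 1 to compound 3 (0.05 log units; within the scatter), not beyond the usual scatter and with no clear direction. Going by these compounds, on that basis compound 3 is estimated at 15000 nM in this assay, with a range from 6000 nM to 40000 nM, an estimate that remains open until the measurement is in hand.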

Compound 3, half-maximal effective concentration: 14000 nM
The estimate for compound 3 lay 1.1-fold (0.03 log units) above the measured number; measured number inside the range.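

In this assay, within the data shown here, methoxy in place of hydrogen on an aromatic carbon of the shared core gives a 1.2-fold lower number from compound 1 to compound 3 (0.08 log units; within the scatter), and this is the only step that can be read. It shows that this place, on a six-membered aromatic ring of carbon only, meta to a fused ring and para to a fused ring, takes a methoxy with its hydrogen-bond acceptor and two heavy atoms without any separation of compound 3 from compound 1 in this read-out. Nothing at hand bears on the reason for this result, so the step stands as an observation only.

Still open, going by these compounds, is whether a carboxylic acid, an amine or a longer chain such as butoxy at this same place would also stay within the scatter of compound 1, and whether methoxy on another aromatic carbon of the core would behave as it does here. Also open, on these data alone, is whether the methoxy step would hold on the background of compound 2, whose entry gives no number to compare against.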